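Adding a Methoxy Group to a Longer-Chain Relative

The source may report more compounds than this note shows. Statements on the series, on what has been measured and on what is new or still open speak of the compounds shown alone.

The measured compounds so far:

Compound 1, `COc1cccc(/C=C/C(=O)c2ccc[nH]2)c1`, with 6200 nM in an assay for inhibition of cytochrome P450 1A1 (Homo sapiens), read by fluorescence, using microsomes, with a stated time of 10 min; on this read-out higher numbers stand for weaker inhibition and lower numbers for stronger inhibition.
Compound 2, `COc1cc(/C=C/C(=O)c2ccc[nH]2)cc(OC)c1`, with 6100 nM in this assay.
Compound 3, `O=C(/C=C/C=C/c1ccccc1)c1ccc[nH]1`, which in this assay reaches only the limit > 20000 nM.

The value for compound 3 is a limit of the assay and not a number; it is the limit described by the limit of > 20000 nM in this assay, at which 1 of the 3 values shown sits.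

Compound 1 and compound 2 share a core and differ by methoxy in place of hydrogen on an aromatic carbon. That step, a 1.0-fold lower number from compound 1 to compound 2 (0.01 log units; within the scatter), lies within the usual scatter, so the two values show no difference worth reading.

Compound 3 has a different core from compound 1; the difference between the two cores is not broken down here.

Compound 4, `COc1ccc(/C=C/C=C/C(=O)c2ccc[nH]2)cc1`, has not yet been measured. It differs from compound 3 by methoxy in place of hydrogen on an aromatic carbon. This is the same kind of change as that from compound 1 to compound 2, but the place is not the same: in compound 2 the new methoxy sits meta to a group of 9 heavy atoms and meta to a methoxy group, while in compound 4 it sits para to a large group.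

Since the matching step in this assay was a 1.0-fold lower number from compound 1 to compound 2 (0.01 log units; within the scatter), the step from compound 3 to compound 4 is expected to be about as small, a step that the limit leaves unreadable from compound 3 to compound 4, resting on that earlier step alone. Compound 4 is therefore estimated at 25000 nM, within 8000 nM to 80000 nM, and the chance that this assay again reports only a limit for compound 4 is high.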

Compound 4, half-maximal inhibitory concentration: > 20000 nM
Compound 4 gave a limit, no number; the forecaster's own chance of this, stated with the estimate: 60%; the middle value lies beyond the limit too.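

In this assay, compound 3 and compound 4 both end at a limit of the assay and not at a number, so the step between them cannot be read: the limit of > 20000 nM in this assay, at which 2 of the 4 values shown sit.

The compounds shown leave open whether methoxy in place of hydrogen changes the inhibition seen with compound 3 at all, and how weak the inhibition by compound 3 and compound 4 really is.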